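A few compounds are considered here, and "the series" means these few. Any claim that something is new, unique, unknown or untested is made for them only; others in the source may bear on it.

Compound 2, `ClCc1ccccc1Cn1cnc2c(Cl)nc(Cl)nc21`, holds the lowest of the two values recorded so far in a functional assay on PC-3 cells (Homo sapiens) for cytotoxicity, read by sulforhodamine B assay, with a stated time of 48 h (a higher number here means a weaker inhibitor of growth, a lower number a stronger inhibitor of growth), giving 1620 nM, while compound 1, `ClCc1ccc(Cn2cnc3c(Cl)ncnc32)cc1`, gives 72400 nM in this assay; the two differ in more than one place, so their gap cannot be traced to a single change. Compound 3, `ClCc1ccccc1Cn1cnc2c(Cl)ncnc21`, is compound 2 with hydrogen in place of chloro on an aromatic carbon, between two ring nitrogen atoms. For the measured compounds named here, since no single step of this kind has been measured, the direction is uncertain; a weakening is thought more likely, by a step estimated as a 4.9-fold higher number from compound 2 to compound 3 (0.69 log units; beyond the scatter). Compound 3 is therefore expected to give about 8000 nM, within 2000 nM to 40000 nM.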

Compound 3, concentration for total growth inhibition: 10500 nM
Beside the measured number, compound 3's estimate is 1.3-fold (0.12 log units) below it; measured number inside the range.
By their numbers in this assay, from the lowest: compound 2; then compound 3; then compound 1.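

In this assay, the chloro on the aromatic carbon between two ring nitrogen atoms matters: replacing it with hydrogen gives a 6.5-fold higher number from compound 2 to compound 3 (0.81 log units; beyond the scatter) in a single change, so removing this chloro weakens growth inhibition. For the compounds shown here, this is the first effect that can be traced to one place, as compound 1 and compound 2 differ in more than one. Nothing measured here explains the size of this step.

Going by these compounds, whether an amine or a methoxy group at this position would match chloro remains open. So does whether chloro there would give a similar step on compound 1.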